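The compounds below may be only part of what the source reports. "The series", "measured", "known", "first", "only" and "open" are said of these compounds alone.

Measured in a toxicity assay on L02 cells (Homo sapiens) for cytotoxicity, read by MTT assay, with a stated time of 72 h; on this read-out higher numbers stand for weaker inhibition and lower numbers for stronger inhibition:
- compound 1 `O=C1c2c[n+]([O-])c3ccccc3c2C(=O)c2c1c1ccccc1n2CCN1CCCC1`: 930 nM
- compound 2 `CN1CCN(CCCn2c3c(c4ccccc42)C(=O)c2c[n+]([O-])c4ccccc4c2C3=O)CC1`: 230 nM
- compound 3 `O=C1c2c[n+]([O-])c3ccccc3c2C(=O)c2c1c1ccccc1n2Cc1cn(C[C@@H](O)CO)nn1`: 490 nM

Compound 3 is placed by two steps: a 1.9-fold lower number from compound 1 to compound 3 (0.28 log units; within the scatter), and a 2.1-fold higher number from compound 2 to compound 3 (0.33 log units; beyond the scatter). The change to compound 4 `O=C1c2c[n+]([O-])c3ccccc3c2C(=O)c2c1c1ccccc1n2CCCN1CCC(O)CC1` is 2-(4-hydroxypiperidin-1-yl)ethyl in place of 1-(2,3-dihydroxypropyl)-1H-1,2,3-triazol-4-yl on a saturated chain carbon bound to an aromatic nitrogen. The second of those steps bears most closely, as it exchanges the same 1-(2,3-dihydroxypropyl)-1H-1,2,3-triazol-4-yl for 2-(4-methylpiperazin-1-yl)ethyl at the same place. However, a 4.0-fold lower number from compound 1 to compound 2 (0.61 log units; beyond the scatter) shows that chains ending in a saturated ring can differ from one another, so only part of that gap is expected to carry over. The expected step is small, toward lower numbers and not beyond the scatter: a 1.4-fold lower number from compound 3 to compound 4 (0.16 log units; within the scatter). Compound 4 is estimated at 340 nM, with an expected range of 120 nM to 900 nM.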

Compound 4, half-maximal inhibitory concentration: 120 nM
For compound 4 the middle estimate is 2.8-fold (0.45 log units) above the measured one; the measured number falls inside the stated range.
By their numbers in this assay, from the lowest: compounds 4 and 2 (each within the scatter of the next); then compounds 3 and 1 (each within the scatter of the next).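

Within the chains ending in a saturated ring, the 4-hydroxypiperidin-1-yl end cannot be told apart from the 4-methylpiperazin-1-yl end in this assay (a 1.9-fold lower number from compound 2 to compound 4 (0.28 log units; within the scatter)). Against the triazole-bearing chain, the 3-(4-hydroxypiperidin-1-yl)propyl chain gives clearly stronger inhibition (a 4.1-fold lower number from compound 3 to compound 4 (0.61 log units; beyond the scatter)). The largest step in the set separates it from the pyrrolidin-1-yl chain (a 7.8-fold lower number from compound 1 to compound 4 (0.89 log units; beyond the scatter)). From the compounds shown here alone, whether an unsubstituted piperidine or a butyl linker would hold this level remains open. Going by these compounds, what drives these steps also remains open, as no supporting data bear on them.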